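Thiophene in Place of Alkyne: Expected Clearance of Compound 4

The compounds below may be only part of what the source reports. "The series", "measured", "known", "first", "only" and "open" are said of these compounds alone.

Compound 1, `Nc1ccc(S(=O)(=O)N2CCN(c3ncc(C(O)(C(F)(F)F)C(F)(F)F)cc3C#CCO)CC2)cn1`, 65 mL.min-1.g-1
Compound 2, `CC(C)(O)C#Cc1cc(C(O)(C(F)(F)F)C(F)(F)F)cnc1N1CCN(S(=O)(=O)c2ccc(N)nc2)CC1`, 16 mL.min-1.g-1
Compound 3, `Nc1ccc(S(=O)(=O)N2CCN(c3ncc(C(O)(C(F)(F)F)C(F)(F)F)cc3C#CCCO)CC2)cn1`, 68 mL.min-1.g-1

These numbers come from an ADME assay (liver) for metabolic stability, with Liver microsome (Rattus norvegicus) as the target, using microsomes and NADPH, with a stated time of 30 min, tested at 1 uM; a lower number here means slower removal, a higher number faster removal of the compound. Compound 2 stands lowest of the three: the step of a 4.1-fold lower number from compound 1 to compound 2 (0.61 log units; beyond the scatter) and the step of a 4.3-fold higher number from compound 2 to compound 3 (0.63 log units; beyond the scatter) both lie beyond the scatter, while compound 1 and compound 3 sit within the scatter of each other.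

Compound 4, `Cc1csc(-c2cc(C(O)(C(F)(F)F)C(F)(F)F)cnc2N2CCN(S(=O)(=O)c3ccc(N)nc3)CC2)c1`, differs from compound 2 by 4-methylthiophen-2-yl in place of 3-hydroxy-3-methylbut-1-yn-1-yl on an aromatic carbon. For the measured compounds named here, no measured step swaps this alkyne chain for a ring; the only steps touching that position, a 4.1-fold lower number from compound 1 to compound 2 (0.61 log units; beyond the scatter) and a 4.3-fold higher number from compound 2 to compound 3 (0.63 log units; beyond the scatter), are modest changes within the chain. A modest upward step is therefore expected, a 3.1-fold higher number from compound 2 to compound 4 (0.49 log units; beyond the scatter). Compound 4 is estimated at 50 mL.min-1.g-1, between 15 mL.min-1.g-1 and 160 mL.min-1.g-1.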

Compound 4, intrinsic clearance in microsomes: 399 mL.min-1.g-1
Estimate against measurement, compound 4: 8.0-fold (0.90 log units) below; measured number above the stated range.
By their numbers in this assay, from the lowest: compound 2; then compounds 1 and 3 (each within the scatter of the next); then compound 4.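

In this assay the swap of the alkyne chain for 4-methylthiophen-2-yl gives a 25-fold higher number from compound 2 to compound 4 (1.40 log units; beyond the scatter) and so moves the number further than either change within the chain did. The ring also stands higher against the two other chains, with a 5.9-fold higher number from compound 3 to compound 4 (0.77 log units; beyond the scatter) and a 6.1-fold higher number from compound 1 to compound 4 (0.79 log units; beyond the scatter) as the steps, so its rise does not depend on which of the three alkyne chains it replaces. Nothing shown here bears on the reason for this rise.

The compounds shown leave open whether the rise follows the thiophene ring itself or its methyl group. They also leave open where an unsubstituted thiophene, a phenyl ring or a chain ending in an amine would fall at this position.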